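Removing Bromine from Two Related Cores: An Expected Step

The source may hold more compounds than are shown below. What is called first, only, known or untested is meant among the compounds shown, and "the series" means these compounds.

The measured compounds:
Compound 1, `Cc1ccc2nc(/N=C3\C(=O)N(CN(C)C)c4cccc(Br)c43)sc2c1`, gives 18000 nM in a functional assay on MCF7 cells (Homo sapiens) for cytotoxicity, read by sulforhodamine B assay, with a stated time of 48 h; a lower number here means a stronger inhibitor of growth, a higher number a weaker inhibitor of growth.
Compound 3, `Cc1ccc2nc(/N=C3\C(=O)N(CN(C)C)c4ccccc43)sc2c1`, gives 29200 nM in this assay.
Compound 2, `CN(C)CN1C(=O)C(=O)c2c(Br)cccc21`, gives 57600 nM in this assay.

Compound 1 and compound 3 share a core and differ in one place: hydrogen in place of bromo on an aromatic carbon. In this assay this change gave a 1.6-fold higher number from compound 1 to compound 3 (0.21 log units; within the scatter), so on this core the bromo contributes little that can be told apart from repeat-to-repeat noise.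

Compound 2 has a different, smaller core than compound 1; the difference between the two cores is not broken down here. Its value in this assay lies within the usual scatter of the value of compound 3, but beyond the scatter from the value of compound 1.

Compound 4, `CN(C)CN1C(=O)C(=O)c2ccccc21`, has not yet been measured. It differs from compound 2 by hydrogen in place of bromo on an aromatic carbon. The place of this change is described in the same words as for the change from compound 1 to compound 3, so it is the same change, now made on the smaller core.

The step from compound 2 to compound 4 in this assay is estimated at a 1.4-fold higher number from compound 2 to compound 4 (0.14 log units; within the scatter), resting on the size of a 1.6-fold higher number from compound 1 to compound 3 (0.21 log units; within the scatter). That rests on a single measured pair and on a different core, so the expected range is kept wide. Compound 4 is expected to give about 80000 nM, most likely between 40000 nM and 160000 nM.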

Compound 4, concentration for 50% growth inhibition: 40500 nM
Estimate against measurement, compound 4: 2.0-fold (0.30 log units) above; low and high end bracket the measured number.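

In this assay, replacing bromo with hydrogen on the smaller core gave a 1.4-fold lower number from compound 2 to compound 4 (0.15 log units; within the scatter), so here too the bromo makes no difference that can be separated from ordinary repeat-to-repeat variation. The two steps appear to point in opposite directions, but that apparent reversal is no evidence that the two cores respond differently to this change: the same change on two cores in this assay, a 1.6-fold higher number (0.21 log units; within the scatter) from compound 1 to compound 3 and a 1.4-fold lower number (0.15 log units; within the scatter) from compound 2 to compound 4, 2.3-fold (0.36 log units) apart, within the scatter of two such steps. What this shows is only that, in these two pairs, swapping bromo for hydrogen has no clear effect on either core; with just two small steps, it does not prove that the change has no effect on other cores, nor does it show that the steps on these two cores are truly identical.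

The compounds shown carry only bromo or hydrogen on this aromatic carbon, so it remains open whether a chloro group, a methoxy group or an amine there would produce a step large enough to stand clear of the scatter. As far as these compounds go, it also remains open whether any such group would behave alike on both cores, which would give a firmer test of carrying a change from one core to the other.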